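Fluoro on the Fused Ring of Compound 1

The compounds below may be only part of what the source reports. "The series", "measured", "known", "first", "only" and "open" are said of these compounds alone.

Compound 1 `Cc1ccc(-c2ccc(C)n2-c2ccc(-c3nc4ccccc4s3)cc2)cc1` is one of three measured compounds that share a core and differ only at the distal aryl ring. In a functional assay on MCF7 cells (Homo sapiens) for cytotoxicity, read by sulforhodamine B assay, with a stated time of 48 h (a lower number here means a stronger inhibitor of growth, a higher number a weaker inhibitor of growth), compound 1 gives 2500 nM. Compound 2 `Cc1ccc(-c2ccc(F)cc2)n1-c1ccc(-c2nc3ccccc3s2)cc1` gives 2620 nM in this assay, and compound 3 `COc1ccc(-c2ccc(C)n2-c2ccc(-c3nc4ccccc4s3)cc2)cc1` gives 2780 nM. The three numbers sit close together: a 1.0-fold higher number from compound 1 to compound 2 (0.02 log units; within the scatter), a 1.1-fold higher number from compound 1 to compound 3 (0.05 log units; within the scatter) and a 1.1-fold higher number from compound 2 to compound 3 (0.03 log units; within the scatter), so compound 1 stands among its neighbours without any separation that the scatter would not cover.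

Compound 4 `Cc1ccc(-c2ccc(C)n2-c2ccc(-c3nc4ccc(F)cc4s3)cc2)cc1` changes a different part of the molecule: fluoro in place of hydrogen on an aromatic carbon. Among the measured compounds shown here, no measured step touches this fused ring; the three steps known here all concern the distal aryl ring and all fall within the scatter. The data therefore give no reason to expect a step in this assay beyond the scatter in either direction, and compound 4 is expected to behave much like compound 1, with an estimated step of no change at the digits printed from compound 1 to compound 4 (within the scatter). Compound 4 is thus estimated at 2500 nM, within a range from 1100 nM to 5700 nM.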

Compound 4, concentration for 50% growth inhibition: 2150 nM
The estimate for compound 4 lay 1.2-fold (0.07 log units) above the measured number; the range from low to high includes it.
By their numbers in this assay, from the lowest: compounds 4, 1, 2 and 3 (each within the scatter of the next).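

The fused ring now has a measured step of its own: fluoro in place of hydrogen on an aromatic carbon of that six-membered ring, meta to a fused ring and para to a fused ring, gives a 1.2-fold lower number from compound 1 to compound 4 (0.07 log units; within the scatter) in this assay. The earlier compounds shown here showed changes only at the distal aryl ring, whereas compound 4 shows that this position on the fused ring also takes a fluoro with no separation from compound 1 that the scatter would not cover. Nothing available on these compounds offers an explanation for this result.

Fluoro is the only group shown at this position, so it remains open whether an amine or a carboxylic acid there would give a step beyond the scatter. Also open, from the compounds shown here alone, is how fluoro at this position would combine with the fluoro or methoxy on the distal aryl ring of compounds 2 and 3.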